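Allylphenol biaryls: methoxy replacing trifluoromethyl

The source may hold more compounds than are shown below. What is called first, only, known or untested is meant among the compounds shown, and "the series" means these compounds.

Measured compounds:
compound 1 `C=CCOc1ccc(-c2ccc(OC)cc2)cc1CC=C`: > 100000 nM
compound 2 `C=CCc1cc(-c2cccc(C(F)(F)F)c2)ccc1O`: 73000 nM

Within the data shown here, in a functional assay on A549 cells (Homo sapiens) for antiproliferative activity, read by MTT assay, with a stated time of 24 h (on this read-out higher numbers stand for weaker inhibition and lower numbers for stronger inhibition), compound 2 gives 73000 nM, the only number among the values shown. Compound 1 gives > 100000 nM in this assay, which is a limit of the assay and not a number (the limit of > 100000 nM in this assay, at which 1 of the 2 values shown sits). Among the measured compounds shown here, no step between measured compounds is available here, so the weak inhibition of compound 2 stands alone as a reference.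

Compound 3 `C=CCc1cc(-c2cccc(OC)c2)ccc1O` has not been measured. It differs from compound 2 as follows (methoxy in place of trifluoromethyl on an aromatic carbon).

Compound 3 is expected to sit close to compound 2, because compound 2 gives 73000 nM, which is already weak. The step of a 1.2-fold higher number from compound 2 to compound 3 (0.09 log units; within the scatter) in this assay is expected to be no larger than a small loss. The estimate for compound 3 is 90000 nM, within the range 30000 nM to 300000 nM, and a limit-only result is a real possibility.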

Compound 3, half-maximal inhibitory concentration: > 100000 nM
Compound 3 was reported as a limit; the forecaster's own chance of this, stated with the estimate: 40%; at least 1.1-fold (0.04 log units) between middle value and limit.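

With methoxy in place of trifluoromethyl on this aromatic carbon, this assay shows an at least 1.3-fold higher number from compound 2 to compound 3 (0.13 log units; that floor lies within the scatter), so this change does not move the series out of weak inhibition. That step is a floor and not a size, and how far compound 3 truly lies from compound 2 cannot be read from it. Compound 3 is reported as a limit and not a number, which leaves compound 2 as the only compound with a number and narrows what the series can show: the limit of > 100000 nM in this assay, at which 2 of the 3 values shown sit.

On these data alone, whether methoxy and trifluoromethyl differ at all at this place in this assay stays open. Also open, as far as these compounds go, is whether an amine or a carboxylic acid on this aromatic carbon would give a number clearly under the limit.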